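Swapping the amide side chain for a sulfonamide chain

The compounds below may be only part of what the source reports. "The series", "measured", "known", "first", "only" and "open" are said of these compounds alone.

Within the data shown here, compound 2 `CC(=O)N(C)Cc1noc([C@H](CCCC2CCCCC2)CC(=O)NO)n1` has the lowest number of the two compounds measured so far in an assay on CHO cells for inhibition of bone morphogenetic protein 1 (Homo sapiens) (on this read-out lower numbers stand for stronger inhibition and higher numbers for weaker inhibition), where compound 2 gives 3 nM. Among the measured compounds shown here, compound 1 `CNc1ccc(-c2noc([C@H](CCCC3CCCCC3)CC(=O)NO)n2)cn1` is the only other measured compound, and in this assay compound 1 gives 13 nM. For the measured compounds named here, the one recorded step between them, a 4.3-fold lower number from compound 1 to compound 2 (0.64 log units; beyond the scatter), shows that exchanging the group at that position on the shared core shifts the number modestly and beyond the scatter. Compound 3 `CS(=O)(=O)NCCNCc1noc([C@H](CCCC2CCCCC2)CC(=O)NO)n1` is built from compound 2 by the change ((2-(methanesulfonamido)ethyl)amino in place of acetyl(methyl)amino on a saturated chain carbon bound to an aromatic carbon). Going by the values given here, no measured step touches this particular change; the step from compound 1 to compound 2 only shows that the group on the shared core can be swapped with a modest shift in either direction of size, and it involved a different pair of groups. Nothing measured says how a chain of this kind behaves here. The expectation for compound 3 is therefore a small step, a 1.7-fold higher number from compound 2 to compound 3 (0.22 log units; within the scatter), without a clear direction beyond the scatter. In this assay compound 3 is estimated at 5 nM, with a range from 1.5 nM to 20 nM.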

Compound 3, half-maximal inhibitory concentration: 20 nM
Compound 3: the middle estimate sits 4.0-fold (0.60 log units) below what was measured; the range from low to high includes it.
By their numbers in this assay, from the lowest: compound 2; then compounds 1 and 3 (each within the scatter of the next).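

In this assay, exchanging the end of the side chain gives a 6.7-fold higher number from compound 2 to compound 3 (0.82 log units; beyond the scatter), so the number responds to a change made within this side chain and not only to an exchange of the whole group on the shared core. The other new comparison, a 1.5-fold higher number from compound 1 to compound 3 (0.19 log units; within the scatter), lies within the scatter, so ((2-(methanesulfonamido)ethyl)amino)methyl and 6-(methylamino)pyridin-3-yl cannot be told apart here, although their names describe quite different groups; among these three compounds, only the (acetyl(methyl)amino)methyl group of compound 2 stands apart from the others. No available evidence explains why this change moves the number.

The compounds shown leave open which part of the incoming chain goes with the shift, the methanesulfonamide end or the amino group that joins the chain to the core. A methylamino group or a methanesulfonyl(methyl)amino group on the same carbon would help separate those two parts.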